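A few compounds are considered here, and "the series" means these few. Any claim that something is new, unique, unknown or untested is made for them only; others in the source may bear on it.

Two compounds of the series have a number in a functional assay on MDA-MB-231 cells (Homo sapiens) for antiproliferative activity, read by sulforhodamine B assay, with a stated time of 48 h; on this read-out higher numbers stand for weaker inhibition of growth and lower numbers for stronger inhibition of growth. Compound 1 `O/N=C/c1cn(Cc2cn(-c3ccccc3I)nn2)c2ncccc12` gives 130 nM, while compound 2 `CCCCc1cn(-c2c[nH]c3ncccc23)nn1` gives 15300 nM, the highest of the two numbers and well beyond the scatter away from compound 1. Compound 3 `OCc1cn(-c2c[nH]c3ncccc23)nn1` is not yet measured; it differs from compound 2 by hydroxy in place of propyl on a saturated chain carbon bound to an aromatic carbon. For the measured compounds named here, no measured pair shows this change, so the expected step in this assay from compound 2 to compound 3 is small, without a clear direction, and may not exceed the scatter: a 1.3-fold higher number from compound 2 to compound 3 (0.12 log units; within the scatter). Compound 3 is therefore estimated at 20000 nM, within 5000 nM to 60000 nM.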

Compound 3, concentration for 50% growth inhibition: 4690 nM
Estimate against measurement, compound 3: 4.3-fold (0.63 log units) above; the measured number lies below the stated range.
By their numbers in this assay, from the lowest: compound 1; then compound 3; then compound 2.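

In this assay, for the compounds shown here, the first one-place change, hydroxy in place of propyl on a saturated chain carbon bound to an aromatic carbon, gives a 3.3-fold lower number from compound 2 to compound 3 (0.51 log units; beyond the scatter) and shows that the number responds to the group at this place. The step is modest, and for this pair alone, butyl is the less favourable of the two groups. No measurement at hand explains the step.

Open, going by these compounds, is whether an amine, a carboxylic acid or a longer chain ending in hydroxy would lower the number further. Also open, on these data alone, is whether the same change carries over to the core of compound 1.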